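Nitro analogue of compound 1 in the growth series

The source may report more compounds than this note shows. Statements on the series, on what has been measured and on what is new or still open speak of the compounds shown alone.

Going by the values given here, compound 1 `O=c1cc(-c2ccccc2)oc2cc(N3COc4ccccc4C3)ccc12` stands lowest of the three measured members. In a functional assay on MCF7 cells (Homo sapiens) for inhibition, read by MTT assay, with a stated time of 48 h, tested at 15 ug/mL (a lower number here means less inhibition of growth, a higher number more inhibition of growth at the concentration tested), compound 1 gives 3.89%. Its nearest neighbour by number is compound 3 `O=c1cc(-c2ccccc2)oc2ccc(N3COc4ccccc4C3)cc12`, which in this assay gives 34%, a gap beyond the scatter. Compound 2 `O=c1cc(-c2ccccc2)oc2ccc(N3COc4c(Cl)cc(Cl)cc4C3)cc12` gives 61.3% in this assay, the highest of the three and furthest from compound 1, again beyond the scatter. Among the compounds with values here, no two measured compounds differ in a single place, so no step between them can be drawn; all that can be said is that both compound 2 and compound 3 lie well above compound 1.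

Compound 4 `O=c1cc(-c2ccccc2)oc2cc(N3COc4c(cccc4[N+](=O)[O-])C3)ccc12` is the unmeasured member. It differs from compound 1 by nitro in place of hydrogen on an aromatic carbon. Nothing measured here shows what a nitro in that place does to the read-out. Compound 1 sits at the floor of the range seen so far, and both other members lie above it; the step from compound 1 to compound 4 is expected to be a number 18.1 percentage points higher from compound 1 to compound 4 (beyond the scatter), a moderate rise in this assay. Compound 4 is thus estimated at 22%, with a range from 4% to 48%.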

Compound 4, percent growth inhibition at one concentration: 1.96%
Beside the measured number, compound 4's estimate is 20 percentage points above it; measured number outside the range, below it.
By their numbers in this assay, from the lowest: compounds 4 and 1 (each within the scatter of the next); then compound 3; then compound 2.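

In this assay, nitro in place of hydrogen on an aromatic carbon, ortho to a fused ring and meta to a fused ring, gives a number 1.9 percentage points lower from compound 1 to compound 4 (within the scatter), the first single-place step available in this series. At this position, then, nitro brings no gain in growth inhibition over hydrogen at the concentration tested, and the read-out of compound 4 cannot be told apart from that of compound 1. Nothing on hand accounts for this result.

From the compounds shown here alone, whether an amine or a carboxylic acid on the same aromatic carbon of compound 1 would raise the read-out remains open. Also open, going by these compounds, is whether nitro at this place on compound 3 would give a step of similar size, since a single step on one core cannot settle that.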